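The source may hold more compounds than are shown below. What is called first, only, known or untested is meant among the compounds shown, and "the series" means these compounds.

Measured so far in a functional assay on HCT-116 cells (Homo sapiens) for antiproliferative activity, read by CCK-8 assay, with a stated time of 72 h; on this read-out higher numbers stand for weaker inhibition and lower numbers for stronger inhibition:
compound 1 `CCOc1cc(C(C)(C)C)ccc1C1=NC(c2ccc(Cl)cc2)C(c2ccc(Cl)cc2)N1C(=O)NCCCCCCCC(=O)NO`: 5030 nM
compound 2 `CCOc1cc(C(C)(C)C)ccc1C1=NC(c2ccc(Cl)cc2)C(c2ccc(Cl)cc2)N1C(=O)NCCCCCCC(=O)Nc1ccccc1N`: 10100 nM
compound 3 `CCOc1cc(C(C)(C)C)ccc1C1=NC(c2ccc(Cl)cc2)C(c2ccc(Cl)cc2)N1C(=O)NCCCCCC(=O)Nc1ccccc1N`: 21800 nM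

Compound 3 carries the highest number of the three at 21800 nM and so shows the weakest inhibition, with its steps to both others beyond the scatter. Next in line is compound 4 `CCOc1cc(C(C)(C)C)ccc1C1=NC(c2ccc(Cl)cc2)C(c2ccc(Cl)cc2)N1C(=O)NCCCCC(=O)Nc1ccccc1N` on the same shared core. The change is (2-aminophenyl)carbamoyl in place of ((2-aminophenyl)carbamoyl)methyl on a saturated chain carbon, four bonds along the chain from an amide-type nitrogen and reads in words as (2-aminophenyl)carbamoyl in place of ((2-aminophenyl)carbamoyl)methyl on a saturated chain carbon, four bonds along the chain from an amide-type nitrogen.

Within the data shown here, the closest precedent is a 2.2-fold higher number from compound 2 to compound 3 (0.33 log units; beyond the scatter) for the same exchange of groups, there five bonds along the chain from an amide-type nitrogen. The other two steps, a 2.0-fold higher number from compound 1 to compound 2 (0.30 log units; within the scatter) and a 4.3-fold higher number from compound 1 to compound 3 (0.64 log units; beyond the scatter), also swap the hydroxycarbamoyl end for the (2-aminophenyl)carbamoyl end and so bear less directly. Among the measured compounds shown here, only one step of the matching kind exists, so no trend is established. A modest further loss is the working expectation, on the assumption that the precedent repeats. The estimate is a 1.7-fold higher number from compound 3 to compound 4 (0.24 log units; within the scatter) in the direction of weaker inhibition. Compound 4 is expected at 38000 nM with an estimated range from 17000 nM to 85000 nM as the likely span.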

Compound 4, half-maximal inhibitory concentration: 13900 nM
Beside the measured number, compound 4's estimate is 2.7-fold (0.44 log units) above it, outside the stated range (below it).
By their numbers in this assay, from the lowest: compounds 1, 2, 4 and 3 (each within the scatter of the next, the first and the last beyond it).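

In this assay, the exchange at this position, on a saturated chain carbon, four bonds along the chain from an amide-type nitrogen, gives a 1.6-fold lower number from compound 3 to compound 4 (0.20 log units; within the scatter) and so does not repeat the step beyond the scatter seen one bond further out in a 2.2-fold higher number from compound 2 to compound 3 (0.33 log units; beyond the scatter) on the same (2-aminophenyl)carbamoyl end. With a 1.4-fold higher number from compound 2 to compound 4 (0.14 log units; within the scatter) also printed alongside, the three (2-aminophenyl)carbamoyl compounds show no steady trend with chain length: compound 2 and compound 4 cannot be told apart, and compound 3 goes against any trend, since only its gap to compound 2 lies beyond the scatter. The step of a 2.8-fold higher number from compound 1 to compound 4 (0.44 log units; beyond the scatter) places compound 4 with compound 3 in lying beyond the scatter from the hydroxycarbamoyl compound 1, while compound 2 does not.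

No measurement at hand explains these numbers or bears on what lies behind them. Open questions are how a hydroxycarbamoyl end would read on the chain of compound 4, and whether a carboxylic acid end or a longer chain carrying the (2-aminophenyl)carbamoyl end would separate from these values beyond the scatter.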